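Trifluoromethyl for ethyl on the pyrimidine arm

The compounds below may be only part of what the source reports. "The series", "measured", "known", "first", "only" and "open" are said of these compounds alone.

Measured in an assay on cells for inhibition of cytochrome P450 11B2, mitochondrial (Homo sapiens), read by HPLC, with a stated time of 90 min; a higher number here means a weaker inhibitor, a lower number a stronger inhibitor:
compound 1 `Fc1ccc2nc(-c3cccnn3)n(C3CC3)c2c1` gives 412 nM
compound 2 `Fc1ccc2nc(-c3ccnnc3)n(C3CC3)c2c1` gives 330 nM
compound 3 `CCc1ncncc1-c1nc2cc(F)c(F)cc2n1C1CC1` gives 8 nM

Compound 3 stands lowest of the three in this assay; its nearest neighbour is compound 2, which sits well above it, and compound 1 sits higher still, both gaps beyond the scatter. Among the measured compounds shown here, the only step among the measured compounds, a 1.2-fold lower number from compound 1 to compound 2 (0.10 log units; within the scatter), concerns the ring on the shared core and not the group that changes here.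

Compound 4 `Fc1cc2nc(-c3cncnc3C(F)(F)F)n(C3CC3)c2cc1F` differs from compound 3 by trifluoromethyl in place of ethyl on an aromatic carbon. For the measured compounds named here, no measured step bears on this exchange: nothing in the data shows what ethyl contributes or what trifluoromethyl does in its place. The expectation for compound 4 therefore rests on compound 3 alone, with an estimated step of a 1.5-fold higher number from compound 3 to compound 4 (0.18 log units; within the scatter), judged most likely to fall within or only slightly beyond the scatter in either direction. Compound 4 is accordingly estimated at 12 nM in this assay, with a plausible range from 3 nM to 45 nM.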

Compound 4, half-maximal inhibitory concentration: 25 nM
Compound 4: the middle estimate sits 2.1-fold (0.32 log units) below what was measured; measured number inside the range.
By their numbers in this assay, from the lowest: compound 3; then compound 4; then compounds 2 and 1 (each within the scatter of the next).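

In this assay, among the compounds shown here, the exchange gives the first reading of how this position on the six-membered aromatic ring with 2 nitrogen responds to the group it carries: a 3.1-fold higher number from compound 3 to compound 4 (0.49 log units; beyond the scatter), a modest step that lies beyond the scatter. For the compounds shown here, the position is therefore not indifferent to this change, yet the step is small enough that ethyl is not the only group giving a low number here, as compound 4 gives 25 nM. Nothing available explains why trifluoromethyl gives the higher number.

Going by these compounds alone, with only two groups compared at this position, it remains open whether a methyl group, a methoxy group, an amine or a longer chain would match compound 3 or move the number further. On these data alone, it is also open whether the same exchange would give a similar step on another core.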